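Fluoro in place of hydroxy on compound 3

The source may report more compounds than this note shows. Statements on the series, on what has been measured and on what is new or still open speak of the compounds shown alone.

Measured so far in a functional assay on cells (Endothelial cell, Bos taurus) for antiproliferative activity; a higher number here means a weaker inhibitor, a lower number a stronger inhibitor:
- compound 1 `COc1ccc(/C=C\c2cc(OC)c(OC)c(OC)c2)cc1[N+](=O)[O-]` gives 135000 nM
- compound 2 `COc1cc(/C=C/c2cc(O)c3ccsc3c2)cc(OC)c1OC` gives 38000 nM
- compound 3 `COc1ccc(/C(F)=C\c2cc(OC)c(OC)c(OC)c2)cc1O` gives 4700 nM

Compound 3 has the lowest number of the three, beyond the scatter from both others. Compound 4 `COc1ccc(/C(F)=C\c2cc(OC)c(OC)c(OC)c2)cc1F` is not yet measured. It carries fluoro in place of hydroxy on an aromatic carbon, ortho to a methoxy group (fluoro in place of hydroxy on an aromatic carbon). Within the data shown here, no measured pair isolates this change, so the expectation is tentative: a moderately higher number in this assay, probably beyond the scatter. The expected size is (a 3.0-fold higher number from compound 3 to compound 4 (0.47 log units; beyond the scatter)). For compound 4 the estimated value is 14000 nM (range 3500 nM to 60000 nM).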

Compound 4, half-maximal inhibitory concentration: 23000 nM
Estimate against measurement, compound 4: 1.6-fold (0.22 log units) below; low and high end bracket the measured number.
By their numbers in this assay, from the lowest: compound 3; then compounds 4 and 2 (each within the scatter of the next); then compound 1.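

In this assay, the change on this aromatic carbon, ortho to a methoxy group, now has a direct reading: fluoro in place of hydroxy gives a 4.9-fold higher number from compound 3 to compound 4 (0.69 log units; beyond the scatter), a modest step beyond the scatter. At this position, on the core shared by these two compounds, hydroxy therefore gives the lower number, and fluoro does not match it. No available evidence accounts for this step. Still open, on these data alone, is how an amino group or a chloro group at this position would compare with hydroxy on the same core.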